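This account rests on a few compounds, and the source may have more. Where it says the series, first, only, none or still open, it means among the compounds named here.

Measured so far:
compound 1 `Nc1ccccc1NC(=O)/C=C/c1ccc(CSc2ccc(F)cc2)cc1` — 7.09%
compound 2 `COc1ccc(SCc2ccc(C(=O)Nc3ccccc3N)cc2)cc1` — 35%

Both were tested in a functional assay on HeLa cells (Homo sapiens) for inhibition, read by CCK-8 assay, with a stated time of 72 h, tested at 2 uM; on this read-out higher numbers stand for more inhibition of growth at the one concentration tested and lower numbers for less inhibition of growth. Compound 2 gives 35%, the higher of the two numbers, and compound 1 gives 7.09%, which lies well beyond the usual scatter below it. Going by the values given here, the two differ in more than one place, so no single step can be drawn between them; the numbers only show that compound 2 slows growth more under these conditions.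

Compound 3 `Nc1ccccc1NC(=O)c1ccc(CSc2ccc(F)cc2)cc1` has not been measured yet. Against compound 2 it shows one change:

fluoro in place of methoxy on an aromatic carbon

Compound 1 also carries the fluoro group on that ring and scores low, but since it differs from compound 2 in a second place as well, it cannot tell how much of its lower number comes from the fluoro alone. On balance a moderate drop is expected, with a step of a number 13 percentage points lower from compound 2 to compound 3 (beyond the scatter) in this assay from the number of compound 2, although a result within the scatter of compound 2 would not be surprising. Compound 3 is therefore estimated at 22%, within 5% to 40%.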

Compound 3, percent growth inhibition at one concentration: 27.9%
Estimate against measurement, compound 3: 5.9 percentage points below; measured number inside the range.
By their numbers in this assay, from the lowest: compound 1; then compounds 3 and 2 (each within the scatter of the next).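

In this assay, fluoro in place of methoxy, para to a large group on the aromatic ring, comes with a number 7.1 percentage points lower from compound 2 to compound 3 (within the scatter). Going by these compounds alone, this gives the first clean reading of the exchange, and at this position the two groups cannot be told apart at the one concentration tested, even though they differ in size and in their count of hydrogen-bond acceptors. Compound 1 also carries the fluoro group, and the printed values of compound 1 at 7.09% and compound 3 at 27.9% show that the fluoro group is present at both ends of that range, while no measurement available here explains why methoxy and fluoro read alike.

Within the data shown here, only two groups have been seen at this position, so it remains open whether an amine, a carboxylic acid or a longer chain such as ethoxy would read the same or give a step beyond the scatter. A single concentration also leaves open whether compound 2 and compound 3 would still look alike across a range of concentrations.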